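Dropping the benzyl arm: what the methyl analogue may give

A few compounds are considered here, and "the series" means these few. Any claim that something is new, unique, unknown or untested is made for them only; others in the source may bear on it.

Measured compounds in a functional assay on RBL cells for antagonist activity at C-X-C chemokine receptor type 1 (Homo sapiens), read by fluorescence and calcium flux, with a stated time of 30 min; a higher number here means a weaker inhibitor, a lower number a stronger inhibitor:
- compound 1 `O=C(Nc1ccc(F)cc1)c1cnc(N(Cc2ccccc2)Cc2ccc(B(O)O)cn2)nc1`: 7 nM
- compound 2 `CN(Cc1cccc(B(O)O)c1)c1ccc(C(=O)Nc2ccc(F)cc2)cn1`: 4100 nM
- compound 3 `CN(Cc1ccc(B(O)O)cn1)c1ccc(C(=O)Nc2ccc(F)cc2)cn1`: 1700 nM

Compound 1 stands lowest of the three numbers: compound 3 lies well above it, and compound 2 further still, both gaps beyond the scatter. The unmeasured compound 4 `CN(Cc1ccc(B(O)O)cn1)c1ncc(C(=O)Nc2ccc(F)cc2)cn1` keeps the core and the boronic acid arm of compound 1 but has hydrogen in place of phenyl on a saturated chain carbon bound to a nitrogen on an aromatic ring; cut one bond further out, benzyl becomes methyl.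

Going by the values given here, only one measured step exists, a 2.4-fold lower number from compound 2 to compound 3 (0.38 log units; beyond the scatter), and it concerns the boronic acid arm, not the benzyl group, so it does not speak to this change directly. What bears on it is that compound 3 carries the same methyl group and the same arm as compound 4 on a closely related core, and its value sits far above compound 1. Compound 4 is therefore expected to move strongly toward a weaker inhibitor, by about a 110-fold higher number from compound 1 to compound 4 (2.06 log units; beyond the scatter), though the core is not identical to that of compound 3.

Compound 4 is estimated at 800 nM, within 150 nM to 4000 nM.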

Compound 4, half-maximal inhibitory concentration: 1700 nM
Beside the measured number, compound 4's estimate is 2.1-fold (0.33 log units) below it, within the range that was stated.
By their numbers in this assay, from the lowest: compound 1; then compounds 3 and 4 (each within the scatter of the next); then compound 2.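

In this assay, putting hydrogen in place of phenyl on a saturated chain carbon bound to a nitrogen on an aromatic ring gives a 240-fold higher number from compound 1 to compound 4 (2.39 log units; beyond the scatter), with the core and the boronic acid arm left unchanged. Going by these compounds alone, this is the first measured change at this position, and it isolates the benzyl to methyl swap, so the large gap can be tied to that one place; the low number of compound 1 is lost once the phenyl goes. Compound 4 also lands within the scatter of compound 3, so the two methyl compounds do not separate on their different cores, and nothing measured here explains why the phenyl matters so much.

Only phenyl and hydrogen are shown at this position, so it remains open whether a smaller carbon group such as an ethyl chain, or a saturated ring such as cyclohexyl, would recover part of the lost activity. From the compounds shown here alone, it is also open whether a benzyl group on the core of compound 3 would bring the same large drop in the number.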